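Hydroxypiperidine Amide Following a Hydroxyethyl Amide

The compounds below may be only part of what the source reports. "The series", "measured", "known", "first", "only" and "open" are said of these compounds alone.

Three measured compounds share one core and differ in a single aromatic substituent. Compound 1 `CS(=O)(=O)c1ccc(-c2cnc3ccc(-c4cccc(S(=O)(=O)CCO)c4)nn23)cc1` gives 8600 nM in a physicochemical assay for solubility, at pH 6.5; on this read-out higher numbers stand for higher solubility and lower numbers for lower solubility. Compound 2 `CS(=O)(=O)c1ccc(-c2cnc3ccc(-c4cccc(C(=O)NCCO)c4)nn23)cc1` sits at the limit (the limit of > 100000 nM in this assay, at which 1 of the 3 values shown sits); in this assay compound 2 gives > 100000 nM, a limit rather than a number. Compound 3 `CS(=O)(=O)c1ccc(-c2cnc3ccc(-c4cccc(S(=O)(=O)C5CC5)c4)nn23)cn1` sits at the limit (the limit of < 5000 nM in this assay, at which 1 of the 3 values shown sits); in this assay compound 3 gives < 5000 nM, again a limit. Going by the values given here, the one measured step, an at least 11-fold higher number from compound 1 to compound 2 (1.06 log units; beyond the scatter), leaves compound 2 at the upper end of the values shown. Compound 4 `CS(=O)(=O)c1ccc(-c2cnc3ccc(-c4cccc(C(=O)N5CCC(O)CC5)c4)nn23)cc1` carries 4-hydroxypiperidin-1-yl in place of (2-hydroxyethyl)amino on a carbonyl carbon. Among the compounds with values here, no measured step alters the group on the carbonyl carbon, so that step only fixes where compound 2 starts. Compound 4 is expected to remain high, with an at least 1.6-fold lower number from compound 2 to compound 4 (0.22 log units; that floor lies within the scatter) as a modest fall. Compound 4 is therefore estimated at 60000 nM, between 15000 nM and 200000 nM.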

Compound 4, solubility: 178000 nM
Estimate against measurement, compound 4: 3.0-fold (0.47 log units) below; measured number inside the range.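

In this assay there is a 21-fold higher number from compound 1 to compound 4 (1.32 log units; beyond the scatter), so the high end of the read-out is no longer held by a single amide with an open chain. A carbonyl carbon carrying the ring of 4-hydroxypiperidin-1-yl also reaches it, and here as a true number. Compound 2 gives > 100000 nM, which is a limit, so the step from it to compound 4 cannot be read.

Going by these compounds, what a plain piperidine or a morpholine on the same carbonyl carbon would give stays open, and so does whether the hydroxyl of compound 4 matters at all.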